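The source may report more compounds than this note shows. Statements on the series, on what has been measured and on what is new or still open speak of the compounds shown alone.

Compound 1 `Cc1ccc(CSc2nc3nc(C)cc(Nc4cc(-c5ccccc5)[nH]n4)n3n2)cc1` gives 6960 nM in a functional assay on MGC-803 cells (Homo sapiens) for inhibition, read by MTT assay, with a stated time of 72 h; a higher number here means a weaker inhibitor, a lower number a stronger inhibitor.
Compound 2 `Cc1cc(Nc2cc(-c3ccccc3)[nH]n2)n2ncnc2n1` gives 21700 nM in this assay.
Compound 3 `Cc1cc(Nc2cc(-c3ccccc3)[nH]n2)n2nc(SCc3c(Cl)cccc3Cl)nc2n1` gives 5280 nM in this assay.

Compound 3 sits at the low end of these three numbers: the step of a 1.3-fold lower number from compound 1 to compound 3 (0.12 log units; within the scatter) lies within the scatter, while a 4.1-fold lower number from compound 2 to compound 3 (0.61 log units; beyond the scatter) is beyond it. Compound 4 `Cc1cc(Nc2cc(-c3ccccc3)[nH]n2)n2nc(SCc3cccc(Br)c3)nc2n1` differs from compound 3 by 3-bromophenyl in place of 2,6-dichlorophenyl on a saturated chain carbon bound to a sulfur. For the measured compounds named here, only one measured step touches that same part of the molecule, a 1.3-fold lower number from compound 1 to compound 3 (0.12 log units; within the scatter), and it stayed within the scatter; the steps of a 3.1-fold higher number from compound 1 to compound 2 (0.49 log units; beyond the scatter) and a 4.1-fold lower number from compound 2 to compound 3 (0.61 log units; beyond the scatter) show that removing the whole group matters modestly, not that the ring pattern does. The expected step in this assay is therefore none beyond the scatter, a 1.0-fold higher number from compound 3 to compound 4 (0.02 log units; within the scatter). Compound 4 is estimated at 5500 nM, within 2500 nM to 12000 nM.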

Compound 4, half-maximal inhibitory concentration: 4820 nM
Estimate against measurement, compound 4: 1.1-fold (0.06 log units) above; measured number inside the range.
By their numbers in this assay, from the lowest: compounds 4, 3 and 1 (each within the scatter of the next); then compound 2.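

In this assay a third ring pattern on this saturated chain carbon makes no clear difference, with a 1.1-fold lower number from compound 3 to compound 4 (0.04 log units; within the scatter) and a 1.4-fold lower number from compound 1 to compound 4 (0.16 log units; within the scatter) both within the scatter, so 4-methylphenyl, 2,6-dichlorophenyl and 3-bromophenyl cannot be told apart here. Having the whole group still counts, as a 4.5-fold lower number from compound 2 to compound 4 (0.65 log units; beyond the scatter) shows beyond the scatter. Nothing available gives a reason for this flat result. Still open, going by these compounds, is whether a carboxylic acid or an amine in place of the ring on that carbon would move the number beyond the scatter.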